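The source may report more compounds than this note shows. Statements on the series, on what has been measured and on what is new or still open speak of the compounds shown alone.

Of the compounds shown here, three from a common core have been tested in an in vitro assay on cells for inhibition of Amine oxidase [flavin-containing] B (Homo sapiens), read by fluorescence and Amplex Red, with stated times of 30 min and 45 min; on this read-out higher numbers stand for weaker inhibition and lower numbers for stronger inhibition. Compound 1 `COc1cccc(CCCC(=O)Nc2nc3ccccc3c(=O)s2)c1` gives 389 nM in this assay. Compound 2 `CN(C(=O)CCCc1ccccc1)c1nc2ccccc2c(=O)s1` gives 53.1 nM. Compound 3 `O=C(C/C=C/c1ccccc1)Nc1nc2ccccc2c(=O)s1` gives 39.8 nM, the lowest number of the three; its number lies within the scatter of that of compound 2, so the two cannot be told apart, while the gap to compound 1 lies beyond the scatter.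

Compound 4 `O=C(C/C=C/c1cccc(Cl)c1)Nc1nc2ccccc2c(=O)s1` has not yet been measured in this assay. It differs from compound 3 in one place: chloro in place of hydrogen on an aromatic carbon. Going by the values given here, no measured pair shows the effect of this change, so the step from compound 3 to compound 4 can only be expected, and it is expected to be small, toward a lower number, estimated at a 1.6-fold lower number from compound 3 to compound 4 (0.20 log units; within the scatter). Compound 4 is therefore estimated to give about 25 nM in this assay, with a range from 8 nM to 80 nM.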

Compound 4, half-maximal inhibitory concentration: > 1000 nM
Compound 4 ended at the assay's limit; the forecaster's own chance of this, stated with the estimate: 2%; at least 40-fold (1.60 log units) between middle value and limit.
By their numbers in this assay, from the lowest: compounds 3 and 2 (each within the scatter of the next); then compound 1. At a limit, above all of these: compound 4.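

Going by these compounds alone, the change from phenyl to 3-chlorophenyl brings an at least 25-fold higher number from compound 3 to compound 4 (1.40 log units; beyond the scatter), so a single added chlorine atom on this aromatic carbon is enough to weaken inhibition sharply, which no earlier pair could show. The value of compound 4 is a limit of the assay, not a number: the limit of > 1000 nM in this assay, at which 1 of the 4 values shown sits. As far as these compounds go, the true size of the step therefore stays unknown.

The compounds shown leave open whether a smaller fluoro or a methyl in the same place would cost as much. They also leave open whether chloro on another carbon of that ring would do the same.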